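Methylsulfanyl for Methoxy: From Compound 1 to Compound 4

The compounds below may be only part of what the source reports. "The series", "measured", "known", "first", "only" and "open" are said of these compounds alone.

Measured compounds:
compound 1 `COc1ccc(-c2ncnn2-c2cc(OC)c(OC)c(OC)c2)cc1` — 950 nM
compound 2 `COc1cc(-c2ncnn2-c2ccc(F)cc2)cc(OC)c1OC` — > 10000 nM
compound 3 `COc1cc(-c2ncnn2-c2ccc([N+](=O)[O-])cc2)cc(OC)c1OC` — > 10000 nM

Among the measured compounds shown here, in a functional assay on K562 cells (Homo sapiens) for antiproliferative activity, read by MTT assay, with a stated time of 72 h (a lower number here means a stronger inhibitor, a higher number a weaker inhibitor), compound 1 gives 950 nM, the only number among the three values shown. Compound 2 gives only a limit of the assay. Compound 3 likewise gives only a limit, both sitting at the limit of > 10000 nM in this assay, at which 2 of the 3 values shown sit. For the measured compounds named here, the one step between measured compounds, a step that the two limits leave unreadable from compound 2 to compound 3, is therefore unreadable, and no measured step bears readably on the change at hand. Compound 4 `COc1cc(-n2ncnc2-c2ccc(SC)cc2)cc(OC)c1OC` differs from compound 1 by methylsulfanyl in place of methoxy on an aromatic carbon. With no readable step to draw on, the step of a 1.1-fold lower number from compound 1 to compound 4 (0.02 log units; within the scatter) is expected to stay within the usual scatter. Compound 4 is therefore estimated at 900 nM, within a range from 300 nM to 3000 nM.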

Compound 4, half-maximal inhibitory concentration: 340 nM
Beside the measured number, compound 4's estimate is 2.6-fold (0.42 log units) above it; the range from low to high includes it.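

Swapping methoxy for methylsulfanyl on an aromatic carbon, para to a large group, gives a 2.8-fold lower number from compound 1 to compound 4 (0.45 log units; beyond the scatter) in this assay. Among the compounds shown here, this is the first readable step, and it shows that a single change at this position can move the number beyond the scatter, which the unreadable step between the earlier limits could not show. Nothing in the data shown accounts for this step. Going by these compounds, it remains open how an amine, a chlorine atom or a longer chain such as ethylsulfanyl would behave at this position.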